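An Acetyl Step in a Level Series

This account rests on a few compounds, and the source may have more. Where it says the series, first, only, none or still open, it means among the compounds named here.

Going by the values given here, in an ADME assay on BJ cells (Homo sapiens) for cytotoxicity, read by CellTiter-Glo, with a stated time of 72 h (on this read-out lower numbers stand for an effect already at smaller amounts and higher numbers for an effect only at larger amounts of compound), compound 3 `CC1=C2CC(C)(C)/C=C/[C@@H](O)/C(C)=C\C3=C[C@H](C)C[C@]3(O2)C1=O` gives 26000 nM and stands level with compound 1 `CC1=C2CC(C)(C)/C=C/C/C(C)=C\C3=C[C@H](C)C[C@]3(O2)C1=O` at 26000 nM and compound 2 `CC(=O)O[C@H]1/C=C/C(C)(C)CC2=C(C)C(=O)[C@]3(C[C@@H](C)C=C3/C=C\1C)O2` at 26000 nM on the numbers so far. Compound 4 `CC(=O)O[C@@H]1/C=C/C(C)(C)CC2=C(C)C(=O)[C@]3(C[C@@H](C)C=C3/C=C\1C)O2` differs from compound 3 by acetyl in place of hydrogen on an oxygen on a saturated carbon and the same difference reads hydroxy to acetoxy. Among the compounds with values here, two measured steps bear on it, and neither has any size: acetoxy in place of hydrogen gave no change at the digits printed from compound 1 to compound 2 (within the scatter) and hydroxy in place of hydrogen gave no change at the digits printed from compound 1 to compound 3 (within the scatter) in the same series. No shift in either direction beyond the scatter is therefore expected in this assay and the estimated change is no change at the digits printed from compound 3 to compound 4 (within the scatter) at most in size. For compound 4 the expected value is 26000 nM within an estimated range of 15000 nM to 45000 nM in this measurement.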

Compound 4, half-maximal effective concentration: 26000 nM
For compound 4 middle estimate and measured number coincide at the digits printed; measured number inside the range.
By their numbers in this assay, from the lowest: compounds 1, 2, 3 and 4 (each within the scatter of the next).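

In this assay, acetyl in place of hydrogen on the oxygen gave no change at the digits printed from compound 3 to compound 4 (within the scatter), and acetoxy in place of hydrogen on the saturated ring carbon gave no change at the digits printed from compound 1 to compound 4 (within the scatter). A change of the drawn configuration at a saturated ring carbon also gave no change at the digits printed from compound 2 to compound 4 (within the scatter). Neither acetyl on this oxygen nor the configuration as drawn separates these compounds here, a reading that rests on one fact: the fact that compounds 2 and 4 differ only in the configuration as drawn

As far as these compounds go, whether an amine, a carboxylic acid or a longer chain at this position would stay level remains open.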